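The source may hold more compounds than are shown below. What is called first, only, known or untested is meant among the compounds shown, and "the series" means these compounds.

Measured compounds:
- compound 1 `COc1ccc(C2CC(c3ccc4ccccc4c3)=NN2C2=NC(=O)/C(=C3\C(=O)Nc4ccccc43)S2)cc1`: 1680 nM
- compound 2 `O=C1N=C(N2N=C(c3ccccc3)CC2c2ccc(Cl)cc2)S/C1=C1/C(=O)Nc2ccccc21`: 190 nM
- compound 3 `COc1ccc(C2=NN(C3=NC(=O)/C(=C4\C(=O)Nc5ccccc54)S3)C(c3ccc(Cl)cc3)C2)cc1`: 100000 nM

In a functional assay on cells (Cancer cell lines, Homo sapiens) for cytotoxicity, read by sulforhodamine B assay, with a stated time of 48 h (a higher number here means a weaker inhibitor of growth, a lower number a stronger inhibitor of growth), compound 3 gives the highest number of the three, so it is the weakest grower inhibitor of this set; compound 1 is the nearest and compound 2 the furthest from it. Among the compounds with values here, the only single-point step recorded is a 530-fold higher number from compound 2 to compound 3 (2.72 log units; beyond the scatter), which shows that putting the methoxy onto the aryl ring at the carbon with a double bond to nitrogen cost a great deal.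

Compound 4 `O=C1N=C(N2N=C(c3ccc4ccccc4c3)CC2c2ccc(Cl)cc2)S/C1=C1/C(=O)Nc2ccccc21` is not yet measured. Against compound 3 the change is naphthalen-2-yl in place of 4-methoxyphenyl on a carbon with a double bond to nitrogen, while the 4-chlorophenyl group stays in place. The step from compound 2 to compound 3 bears directly, in reverse: taking the methoxy away should recover most of what was lost. Compound 1, which carries naphthalen-2-yl at this position but 4-methoxyphenyl instead of 4-chlorophenyl on the other ring carbon, gives 1680 nM, which suggests the naphthalen-2-yl group is tolerated and sits in the active range. A large drop in this assay is therefore expected, a 200-fold lower number from compound 3 to compound 4 (2.30 log units; beyond the scatter), landing between the numbers of compound 2 and compound 1.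

Compound 4 is estimated at 500 nM, with a range of 100 nM to 3000 nM.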

Compound 4, concentration for 50% growth inhibition: 530 nM
The estimate for compound 4 lay 1.1-fold (0.03 log units) below the measured number, within the range that was stated.
By their numbers in this assay, from the lowest: compound 2; then compound 4; then compound 1; then compound 3.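

In this assay, naphthalen-2-yl in place of 4-methoxyphenyl on the carbon with a double bond to nitrogen gives a 190-fold lower number from compound 3 to compound 4 (2.28 log units; beyond the scatter), so the poor number of compound 3 does not extend to every larger aryl group at this place. Against phenyl at the same carbon, naphthalen-2-yl gives a 2.8-fold higher number from compound 2 to compound 4 (0.45 log units; beyond the scatter), a modest cost; the number therefore does not follow the heavy-atom count of the group, as compound 3, with 4-methoxyphenyl, stands far above compound 4 despite carrying the group with fewer heavy atoms. With naphthalen-2-yl held fixed, chloro in place of methoxy on the other aryl group gives a 3.2-fold lower number from compound 1 to compound 4 (0.50 log units; beyond the scatter), which adds a first read of that second site and shows a modest change there.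

No measurement shown here accounts for these differences. Whether the large loss belongs to methoxy itself stays open, since the compounds shown do not include a 4-hydroxyphenyl, 4-methylphenyl or 4-aminophenyl group on the carbon with a double bond to nitrogen, nor naphthalen-1-yl there.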